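Ethyl capping of an acid versus a phenol

A few compounds are considered here, and "the series" means these few. Any claim that something is new, unique, unknown or untested is made for them only; others in the source may bear on it.

Compound 1 `O=C(O)c1cnc(-c2ccccc2F)[nH]c1=O` gives 5 mg/kg in a functional assay on the whole organism (strain Sprague-Dawley) for inhibition, with Rattus norvegicus as the target, with a stated time of 10 min; on this read-out higher numbers stand for an effect only at larger amounts of compound and lower numbers for an effect already at smaller amounts. Compound 2 `O=C(O)c1cnc(-c2ccccc2O)[nH]c1=O` reaches only the limit of > 5 mg/kg in this assay, so no number stands behind it. Compound 3 `CCOc1ccccc1-c1ncc(C(=O)O)c(=O)[nH]1` gives 0.5 mg/kg in this assay. The step of a 10-fold lower number from compound 1 to compound 3 (1.00 log units; beyond the scatter) follows ethoxy in place of fluoro on an aromatic carbon. As far as these compounds go, the step of a number no lower from compound 1 to compound 2 (the limit leaves the size open) stays open, as the reading rests on (the limit of > 5 mg/kg in this assay, at which 1 of the 3 values shown sits). The step of an at least 10-fold lower number from compound 2 to compound 3 (1.00 log units; beyond the scatter) follows (ethyl in place of hydrogen on an oxygen on an aromatic ring).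

The cores of compound 1 and compound 2 differ by fluoro in place of hydroxy on an aromatic carbon. Compound 4 `CCOC(=O)c1cnc(-c2ccccc2F)[nH]c1=O` has not been measured in this assay; it differs from compound 1 by ethyl in place of hydrogen on an oxygen next to a carbonyl group. This is the same kind of change as from compound 2 to compound 3, not the same: there the place is on an oxygen on an aromatic ring whose other neighbours are aromatic carbon, here on an oxygen next to a carbonyl group whose other neighbours are the carbonyl carbon. A step of a 2.0-fold lower number from compound 1 to compound 4 (0.30 log units; within the scatter) is expected, set beside the measured at least 10-fold lower number from compound 2 to compound 3 (1.00 log units; beyond the scatter) but taken smaller, since the place differs. Compound 4 is estimated at 2.5 mg/kg, between 0.8 mg/kg and 8 mg/kg.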

Compound 4, dose for 50% inhibition: > 10 mg/kg
Compound 4 was reported as a limit; the forecaster's own chance of this, stated with the estimate: 25%; at least 4.0-fold (0.60 log units) between middle value and limit.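

In this assay compound 4 gives > 10 mg/kg, which is a limit. Ethyl on an oxygen next to a carbonyl group reads as an at least 2.0-fold higher number from compound 1 to compound 4 (0.30 log units; that floor lies within the scatter), so the gain seen when ethyl caps the hydroxy group of compound 2 does not carry over to the carboxy group of compound 1: the same change on two cores in this assay, an at least 10-fold lower number (1.00 log units; beyond the scatter) from compound 2 to compound 3 and an at least 2.0-fold higher number (0.30 log units; that floor lies within the scatter) from compound 1 to compound 4, at least 20-fold (1.30 log units) apart, beyond the scatter of two such steps. This does not give the full size of either step, and it does not separate the place of the change from the difference between the cores, since the two steps differ in both.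

The compounds shown leave open whether an ethoxycarbonyl group on the core of compound 3 would track compound 4, which would test the same place on a second core. Also open, as far as these compounds go, are a methyl group or a longer chain on that oxygen, and an amide in place of the carboxy group, which would show whether the ethyl group itself or the loss of the free acid sets the result.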